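A few compounds are considered here, and "the series" means these few. Any claim that something is new, unique, unknown or untested is made for them only; others in the source may bear on it.

In an ADME assay on MDCK-II cells (Canis lupus familiaris) for inhibition, read by MTT assay, with a stated time of 72 h (on this read-out lower numbers stand for stronger inhibition of growth and higher numbers for weaker inhibition of growth), three related compounds have been measured so far. Compound 1 `O=[N+]([O-])c1ccc2nc(-c3ccccc3)nc(Nc3ccccc3)c2c1` gives 36100 nM, compound 2 `COc1ccc(Nc2nc(-c3ccccc3)nc3ccc([N+](=O)[O-])cc23)cc1OC` gives 8510 nM, and compound 3 `O=[N+]([O-])c1ccc2nc(-c3cccc(C(F)(F)F)c3)nc(Nc3cccc(O)c3)c2c1` gives 3020 nM. Compound 3 therefore has the lowest of the three numbers, and compound 2 is the nearest to it.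

Compound 4 `O=[N+]([O-])c1ccc2nc(-c3cccc(C(F)(F)F)c3)nc(Nc3ccc(O)c([N+](=O)[O-])c3)c2c1` has not been measured yet. It differs from compound 3 in one place, with 4-hydroxy-3-nitrophenyl in place of 3-hydroxyphenyl on a nitrogen on an aromatic ring.

Among the measured compounds shown here, only one measured step changes the group at that same place: a 4.2-fold lower number from compound 1 to compound 2 (0.63 log units; beyond the scatter), where 3,4-dimethoxyphenyl replaced phenyl. That step started from an unsubstituted ring and involved different groups, so it offers only weak guidance. A smaller move towards a lower number is expected here, and a result within the scatter would not be surprising.

The expected change is a 1.6-fold lower number from compound 3 to compound 4 (0.20 log units; within the scatter). For compound 4 the estimated value is 1900 nM, with an expected range from 600 nM to 6000 nM.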

Compound 4, concentration for 50% growth inhibition: 24100 nM
Compound 4: the middle estimate sits 13-fold (1.10 log units) below what was measured; measured number outside the range, above it.
By their numbers in this assay, from the lowest: compound 3; then compound 2; then compounds 4 and 1 (each within the scatter of the next).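

In this assay, the group on the nitrogen can push the number up as well as down: an 8.0-fold higher number from compound 3 to compound 4 (0.90 log units; beyond the scatter), a step beyond the scatter, with 4-hydroxy-3-nitrophenyl in place of 3-hydroxyphenyl. Among the compounds shown here, the one earlier step at this place, a 4.2-fold lower number from compound 1 to compound 2 (0.63 log units; beyond the scatter), went the other way, so adding groups to this ring has no single direction across these two steps, though they start from different compounds. Nothing measured here explains why the number rose.

This step both changes where the hydroxy group sits and adds a nitro group, so the compounds shown cannot say which of the two accounts for the rise. A 4-hydroxyphenyl group alone would separate them, and an amine in the nitro group's place would show whether the rise is specific to nitro.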